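Swapping the sulfonyl group on the ring amine

The compounds below may be only part of what the source reports. "The series", "measured", "known", "first", "only" and "open" are said of these compounds alone.

Values in a functional assay on MDA-MB-436 cells (Homo sapiens) for antiproliferative activity, read by MTT assay, with a stated time of 48 h (on this read-out higher numbers stand for weaker inhibition and lower numbers for stronger inhibition), follow

Compound 1 `C=CS(=O)(=O)N1CCN(c2ncnc3sc(-c4cccc5ccccc45)cc23)CC1` gives 28100 nM
Compound 2 `C=CS(=O)(=O)N1CCN(c2ncnc3sc(-c4ccc(N5CCN(C)CC5)cc4)cc23)[C@@H](C)C1` gives 6920 nM
Compound 3 `CN1CCN(c2ccc(-c3cc4c(N5CCN(S(=O)(=O)/C=C/c6ccccc6)CC5)ncnc4s3)cc2)CC1` gives 8670 nM

Compound 3 sits within the scatter of compound 2, while compound 1 reads higher, beyond the scatter. Compound 4 `CCCNC(=O)N1CCN(c2ncnc3sc(-c4ccc(N5CCN(C)CC5)cc4)cc23)CC1` carries propylcarbamoyl in place of (2-phenylethenyl)sulfonyl on an amine nitrogen in a ring and is otherwise the same as compound 3. For the measured compounds named here, no measured pair isolates this change, so the expectation in this assay is anchored on compound 3 at 8670 nM and no step beyond the scatter is foreseen in either direction. The estimated shift is a 1.0-fold higher number from compound 3 to compound 4 (0.02 log units; within the scatter) and stays within the scatter. For compound 4 the estimated value is 9000 nM with an expected range from 3000 nM to 27000 nM.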

Compound 4, half-maximal inhibitory concentration: 12400 nM
Compound 4: the middle estimate sits 1.4-fold (0.14 log units) below what was measured; measured number inside the range.
By their numbers in this assay, from the lowest: compounds 2, 3 and 4 (each within the scatter of the next); then compound 1.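

For the compounds shown here, on the amine nitrogen in a ring, this assay gives a 1.4-fold higher number from compound 3 to compound 4 (0.16 log units; within the scatter), the first one-place reading at this position. In this pair, neither the sulfonyl link nor the six-membered aromatic ring of (2-phenylethenyl)sulfonyl is required to stay within the scatter of compound 3, even with the smaller propylcarbamoyl carrying a hydrogen-bond donor. No available evidence accounts for this result.

From the compounds shown here alone, it remains open whether a longer chain or a benzoyl group on this nitrogen would give a step beyond the scatter. Going by these compounds, the role of the amide hydrogen also remains open, and a dimethylcarbamoyl group would address it.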